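One Arm Exchanged on the Core of Compound 1

A few compounds are considered here, and "the series" means these few. Any claim that something is new, unique, unknown or untested is made for them only; others in the source may bear on it.

compound 1 `CCOC(=O)C(C)C(O)(c1ccc(OC)c(OC)c1OC)c1cccc2ccccc12`: > 20000 nM
compound 2 `COc1ccc(C(c2ccccc2O)c2cccc3ccccc23)c(OC)c1OC`: 16600 nM
compound 3 `COc1cc(COC(c2ccc(OC)c(OC)c2OC)c2cccc3ccccc23)cc(OC)c1`: > 20000 nM

All three were tested in a functional assay on MCF7 cells (Homo sapiens) for inhibition, read by sulforhodamine B assay, with a stated time of 48 h; a lower number here means a stronger inhibitor, a higher number a weaker inhibitor. Compound 1 gives only a limit there, > 20000 nM, not a number. Compound 3 likewise returns only a limit, > 20000 nM. Compound 2 alone gives a number, 16600 nM. Compound 1 therefore stands at the limit of > 20000 nM in this assay, at which 2 of the 3 values shown sit, the limit end of everything shown, with no measured number to build from. Compound 4 `COc1ccc(C(O)(C/C=C\c2ccccc2)c2cccc3ccccc23)c(OC)c1OC` has not yet been measured; it differs from compound 1 by 3-phenylprop-2-en-1-yl in place of 1-(ethoxycarbonyl)ethyl on a saturated chain carbon bound to two aromatic carbons and an oxygen on a saturated carbon. Among the compounds with values here, no measured pair tests such a change, so the step from compound 1 is expected to be small, leaning toward stronger inhibition, an at least 1.4-fold lower number from compound 1 to compound 4 (0.15 log units; that floor lies within the scatter), though the starting limit leaves this uncertain. Compound 4 is expected to give about 14000 nM, within 4000 nM to 40000 nM.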

Compound 4, half-maximal inhibitory concentration: 10200 nM
Compound 4: the middle estimate sits 1.4-fold (0.14 log units) above what was measured; the range from low to high includes it.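

In this assay, within the data shown here, 3-phenylprop-2-en-1-yl in place of 1-(ethoxycarbonyl)ethyl gives the first readable step at this position: an at least 1.9-fold lower number from compound 1 to compound 4 (0.29 log units; that floor lies within the scatter). The value of compound 1 is a limit and not a number: the limit of > 20000 nM in this assay, at which 2 of the 4 values shown sit. The step shows that an arm of carbon only, with no hydrogen-bond acceptors, still returns a measured number on this carbon, so the ethoxycarbonyl part is not needed for that. The compounds shown leave open how much of the step rests on the phenyl ring and how much on the chain, and how an amine or a carboxylic acid at the end of the arm would read.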